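A Second Hydroxy Group on a Cytotoxicity-Inactive Scaffold

A few compounds are considered here, and "the series" means these few. Any claim that something is new, unique, unknown or untested is made for them only; others in the source may bear on it.

Measured so far:
- compound 1, `COc1cc2c(cc1O)O[C@H](c1ccccc1)[C@@H](O)C2=O`: > 100000 nM
- compound 2, `COc1ccc(-c2coc3cc(O)ccc3c2=O)c(O)c1`: > 100000 nM

In a functional assay on A549 cells (Homo sapiens) for cytotoxicity, read by MTT assay, with a stated time of 72 h (on this read-out higher numbers stand for weaker inhibition and lower numbers for stronger inhibition), compound 1 gives only a limit, > 100000 nM. Compound 2 likewise gives only a limit in this assay, > 100000 nM. Both values therefore sit at the limit of > 100000 nM in this assay, at which 2 of the 2 values shown sit, so compound 2 stands at that limit and the numbers allow no ranking of the two.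

Compound 3, `COc1ccc(-c2coc3cc(O)cc(O)c3c2=O)c(O)c1`, differs from compound 2 by hydroxy in place of hydrogen on an aromatic carbon. For the measured compounds named here, no step between measured compounds exists to guide this change, and with both measured values at the limit there is no sign of measurable cytotoxicity on this scaffold. The expected step, a step that the limit leaves unreadable from compound 2 to compound 3, is estimated as none beyond the usual scatter. Compound 3 is therefore estimated at 150000 nM, with a range from 50000 nM to 500000 nM, and most likely the assay will again report only a limit.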

Compound 3, half-maximal inhibitory concentration: > 100000 nM
Compound 3: only a limit was reported; the forecaster's own chance of this, stated with the estimate: 85%; the middle value lies beyond the limit too.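

Compound 2 and compound 3 both give only a limit, so no step can be read between them: the limit of > 100000 nM in this assay, at which 3 of the 3 values shown sit. The compounds shown leave open whether the hydroxy group changes cytotoxicity at all, and whether any related compound gives a measurable value in this assay.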